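This account rests on a few compounds, and the source may have more. Where it says the series, first, only, none or still open, it means among the compounds named here.

Measured compounds:
- compound 1 `COc1ccc2c(c1)CCCC2NC(=O)C[C@@H]1C(=O)NC=CN1S(=O)(=O)c1ccc(C)cc1`: 8.95 nM
- compound 2 `Cc1ccc(S(=O)(=O)N2C=CNC(=O)[C@H]2CC(=O)NC2CCCCC2)cc1`: 990 nM

In an in vitro functional assay on cells for antagonist activity at B1 bradykinin receptor (Homo sapiens), read by luminescence and calcium flux, with a stated time of 2 h (a lower number here means a stronger inhibitor, a higher number a weaker inhibitor), compound 1 gives 8.95 nM. Compound 2 has the highest number of the two, and its nearest neighbour, compound 1, sits at a lower number by a gap that is beyond the scatter, so compound 2 is the weaker inhibitor of this pair.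

Compound 3 `CCN1CC[C@H](NC(=O)C[C@@H]2C(=O)NC=CN2S(=O)(=O)c2ccc(C)cc2)C(C)(C)C1` is still to be measured. It differs from compound 2 in one place: a group of 10 heavy atoms (9 carbon, 1 nitrogen; one six-membered non-aromatic ring with 1 hetero atom) in place of a group of 6 heavy atoms (6 carbon; one six-membered non-aromatic ring of carbon only), on an amide-type nitrogen. This is the group carried by the amide nitrogen on the other side of the shared core.

For the measured compounds named here, with no measured pair of this kind, the size of the step is open. The expectation is that the change moves compound 3 to a lower number than compound 2, a step of a 33-fold lower number from compound 2 to compound 3 (1.52 log units; beyond the scatter) in this assay, though with wide uncertainty. Compound 3 is estimated at 30 nM, within a range of 5 nM to 200 nM.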

Compound 3, half-maximal inhibitory concentration: 0.63 nM
For compound 3 the middle estimate is 48-fold (1.68 log units) above the measured one, and the stated range ends above it.
By their numbers in this assay, from the lowest: compound 3; then compound 1; then compound 2.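

Until now, the only direct view of the group on this amide-type nitrogen was cyclohexyl in compound 2, which left open how much this position could matter. In this assay, replacing cyclohexyl with the larger six-membered ring that holds one nitrogen gives a 1600-fold lower number from compound 2 to compound 3 (3.20 log units; beyond the scatter). This large step shows that the change in this one group can turn a weak inhibitor into a very strong one. No measurement shown explains the gain.

Both the ring nitrogen and the extra carbon atoms enter together, so it remains open which of them accounts for the step. A plain piperidine ring with no added carbon groups, or a cyclohexyl ring carrying an ethyl group, would help separate the two.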